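Geranyl ether in place of the benzyl ether

The source may hold more compounds than are shown below. What is called first, only, known or untested is meant among the compounds shown, and "the series" means these compounds.

Of the compounds shown here, two have so far been measured in a functional assay on PANC-1 cells (Homo sapiens) for inhibition, read by MTT assay, with a stated time of 24 h, tested at 10 uM; a higher number here means more inhibition at the concentration tested (going by the name of the read-out), a lower number less inhibition. Compound 1 `CC(C)=CCC/C(C)=C/COc1cc(=O)n(CCCO)c2c1CC(CC=C(C)C)C(C)(C)C2` gives 10.6%, while compound 2 `CC(C)=CCC/C(C)=C/CC1Cc2c(OCc3ccccc3)cc(=O)n(CCCO)c2CC1(C)C` gives 46.5%, the higher of the two numbers, with a gap to compound 1 that lies beyond the usual scatter. Compound 3 `CC(C)=CCC/C(C)=C/COc1cc(=O)n(CCCO)c2c1CC(C/C=C(\C)CCC=C(C)C)C(C)(C)C2` keeps the core of compound 2 and changes only the ether: 2,6-dimethylhepta-1,5-dien-1-yl in place of phenyl on a saturated chain carbon bound to an oxygen on an aromatic ring. The same kind of ether is already present in compound 1, which differs from compound 3 only in the chain on the saturated ring. The expectation for compound 3 therefore leans toward the weaker side, because compound 1 with the same ether gives 10.6%. The step of a number 28.5 percentage points lower from compound 2 to compound 3 (beyond the scatter) is expected to be a loss beyond the scatter. Compound 3 is estimated at 18%, with a range from 3% to 40%.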

Compound 3, a percentage reported as inhibition, at one concentration (the size of the read-out at that concentration, not a potency): 15.8%
The estimate for compound 3 lay 2.2 percentage points above the measured number, and the stated range covers the measured number.
By their numbers in this assay, from the lowest: compounds 1 and 3 (each within the scatter of the next); then compound 2.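

In this assay, phenyl gives way to 2,6-dimethylhepta-1,5-dien-1-yl on a saturated chain carbon bound to an oxygen on an aromatic ring, and this single change brings a number 30.7 percentage points lower from compound 2 to compound 3 (beyond the scatter) and so shows that this position responds to the choice of ether. The second change, 3-methylbut-2-en-1-yl in place of hydrogen on a saturated chain carbon bound to a double-bonded chain carbon, brings a number 5.2 percentage points higher from compound 1 to compound 3 (within the scatter) and so leaves no readable effect of that chain while the 3,7-dimethylocta-2,6-dien-1-yl ether is present. Nothing at hand gives a reason for either step.

From the compounds shown here alone, what a pyridylmethyl ether or a plain methyl ether would give at this position stays open. Going by these compounds, it also stays open whether the chain on the saturated ring matters once the benzyl ether is in place.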